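The source may report more compounds than this note shows. Statements on the series, on what has been measured and on what is new or still open speak of the compounds shown alone.

Compound 1 `C#Cc1cn([C@@H]2O[C@H](CO)[C@@H](O)[C@H]2O)c2ncnc(OC)c12` gives 190 nM
Compound 2 `C#Cc1cn([C@@H]2O[C@H](CO)[C@@H](O)[C@H]2O)c2ncnc(N(C)C)c12` gives 290 nM
Compound 3 `C#Cc1cn([C@@H]2O[C@H](CO)[C@@H](O)[C@H]2O)c2ncnc(C)c12` gives 1110 nM

These three compounds share one core and were all tested in a functional assay on HL-60 cells (Homo sapiens) for antiproliferative activity, read by XTT assay, with a stated time of 72 h; a lower number here means a stronger inhibitor, a higher number a weaker inhibitor. Compound 2 holds the second highest number of the three. Its nearest neighbour is compound 1, and the step of a 1.5-fold higher number from compound 1 to compound 2 (0.18 log units; within the scatter) lies within the scatter, so the two cannot be told apart. The step of a 3.8-fold higher number from compound 2 to compound 3 (0.58 log units; beyond the scatter) is beyond the scatter, as is a 5.8-fold higher number from compound 1 to compound 3 (0.77 log units; beyond the scatter), so compound 3 stands apart from both.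

Compound 4 `CN(C)c1ncnc2c1c(-c1cccs1)cn2[C@@H]1O[C@H](CO)[C@@H](O)[C@H]1O` is not yet measured. It differs from compound 2 in one place: thiophen-2-yl in place of ethynyl on an aromatic carbon. Among the measured compounds shown here, none of the measured steps bears on this change. All three of them swap the group on a different aromatic carbon of the core while the ethynyl stays in place, so nothing measured here tells how trading the ethynyl for a larger ring group will read out in this assay. The expectation therefore rests only on compound 2 itself, with wide uncertainty in both directions. Compound 4 is estimated at 300 nM, within a range from 60 nM to 1500 nM, which would mean an expected step of a 1.0-fold higher number from compound 2 to compound 4 (0.01 log units; within the scatter).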

Compound 4, half-maximal inhibitory concentration: 11800 nM
Compound 4: middle estimate off by 39-fold (1.59 log units), on the low side; the measured number lies above the stated range.
By their numbers in this assay, from the lowest: compounds 1 and 2 (each within the scatter of the next); then compound 3; then compound 4.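

In this assay every earlier step changed the group on a different aromatic carbon of the shared core, and the largest of them was a 5.8-fold higher number from compound 1 to compound 3 (0.77 log units; beyond the scatter) in size. Among the compounds shown here, the carbon that carries the ethynyl, two ring bonds from the ring nitrogen, now changes for the first time: thiophen-2-yl in place of ethynyl gives a 41-fold higher number from compound 2 to compound 4 (1.61 log units; beyond the scatter) and so a far larger step than any seen before, which shows that in this pair the position does not tolerate this swap without a heavy loss of antiproliferative activity. No measurement at hand says why the number rises so far.

The compounds shown leave open whether this loss belongs to thiophen-2-yl alone or to any group larger than ethynyl, and a phenyl ring, a furan-2-yl ring or a short chain such as ethyl on that aromatic carbon would help to separate these cases. For the compounds shown here, it also stays open whether the same swap costs as much when methoxy or methyl replaces dimethylamino, as only one pair speaks to this change so far.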